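From thiophen-2-yl to phenyl on a shared core

This account rests on a few compounds, and the source may have more. Where it says the series, first, only, none or still open, it means among the compounds named here.

Compound 1 `Nc1nc2c(c(-c3ccco3)cn2[C@@H]2O[C@H](CO)[C@@H](O)[C@H]2O)c(=O)[nH]1`: > 20000 nM
Compound 2 `Nc1nc2c(c(-c3ccoc3)cn2[C@@H]2O[C@H](CO)[C@@H](O)[C@H]2O)c(=O)[nH]1`: > 20000 nM
Compound 3 `Nc1nc2c(c(-c3cccs3)cn2[C@@H]2O[C@H](CO)[C@@H](O)[C@H]2O)c(=O)[nH]1`: > 20000 nM

All three entries come from a functional assay on A549 cells (Homo sapiens), read by MTT assay, with a stated time of 72 h (on this read-out lower numbers stand for stronger inhibition and higher numbers for weaker inhibition), and each is a limit of the assay, not a number. Compound 3 stands at the limit > 20000 nM. The same holds across the series: the limit of > 20000 nM in this assay, at which 3 of the 3 values shown sit. No order among the three compounds can be read from these results.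

Compound 4 `Nc1nc2c(c(-c3ccccc3)cn2[C@@H]2O[C@H](CO)[C@@H](O)[C@H]2O)c(=O)[nH]1` keeps the shared core and changes one group: phenyl in place of thiophen-2-yl on an aromatic carbon. Three measured exchanges of one aromatic ring for another bear on this change: a step that the two limits leave unreadable from compound 1 to compound 2, a step that the two limits leave unreadable from compound 1 to compound 3 and a step that the two limits leave unreadable from compound 2 to compound 3. None has a readable size, so none gives a direction, and no clear step is expected in this assay. Compound 4 will probably be reported only as a limit too. The expected change is a step that the limit leaves unreadable from compound 3 to compound 4. For compound 4 the estimated value is 25000 nM, with an expected range from 12000 nM to 50000 nM.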

Compound 4, half-maximal inhibitory concentration: > 100000 nM
Compound 4: a limit, no number; the forecaster's own chance of this, stated with the estimate: 90%; middle value at least 4.0-fold (0.60 log units) away from the limit.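

Among the compounds shown here, compound 4 also gives only a limit in this assay, so no step from compound 1, compound 2 or compound 3 to compound 4 can be read. The compounds shown leave open whether these four aromatic groups on the shared core differ at all in this assay.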